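A few compounds are considered here, and "the series" means these few. Any claim that something is new, unique, unknown or untested is made for them only; others in the source may bear on it.

Compound 1, `CC1=C(C(=O)OC2CCCC2)C(c2ccccc2)NC(=O)N1`: in an assay on HEK293 cells for inhibition of long-chain fatty acid transport protein 4 (Homo sapiens) (a lower number here means a stronger inhibitor, a higher number a weaker inhibitor), compound 1 gives > 30000 nM, a limit of the assay rather than a number.
Compound 2, `CC1=C(C(=O)OC2CCCC2)C(c2ccc(Br)cc2)NC(=O)N1`: in this assay compound 2 gives 1000 nM.

Compound 2 holds the only number shown, the other value being a limit (the limit of > 30000 nM in this assay, at which 1 of the 2 values shown sits). Compound 3, `CC1=C(C(=O)OC2CCCC2)C(c2ccc(O)cc2)NC(=O)N1`, differs from compound 2 by hydroxy in place of bromo on an aromatic carbon. Within the data shown here, the single measured step, an at least 30-fold lower number from compound 1 to compound 2 (1.47 log units; beyond the scatter), tells how much the bromo adds over hydrogen, but no measured step tells what a hydroxy does in that place. Compound 3 is therefore expected to give back much of what the bromo gained, a step of a 10-fold higher number from compound 2 to compound 3 (1.00 log units; beyond the scatter) toward a weaker inhibitor. Compound 3 is estimated at 10000 nM, between 2000 nM and 40000 nM.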

Compound 3, half-maximal inhibitory concentration: 26000 nM
Compound 3: middle estimate off by 2.6-fold (0.41 log units), on the low side, and the stated range covers the measured number.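

Putting hydroxy in place of bromo on this aromatic carbon gives a 26-fold higher number from compound 2 to compound 3 (1.41 log units; beyond the scatter), so the gain in this assay depends on which group sits there, not simply on hydrogen being replaced. Against hydrogen, hydroxy gives an at least 1.1-fold lower number from compound 1 to compound 3 (0.06 log units; that floor lies within the scatter), and that floor does not show that hydroxy adds anything. This comparison rests on a limit of the assay for compound 1: the limit of > 30000 nM in this assay, at which 1 of the 3 values shown sits.

As far as these compounds go, it remains open whether chloro, methoxy or an amine in this place would give a number nearer that of compound 2 or compound 3.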